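Taking the chloro group off compound 2

The compounds below may be only part of what the source reports. "The series", "measured", "known", "first", "only" and "open" are said of these compounds alone.

In a functional assay on the whole organism (Hindlimb, strain albino) with Mus musculus as the target, in the maximal electroshock model, with a stated time of 0.5 h (on this read-out lower numbers stand for an effect already at smaller amounts and higher numbers for an effect only at larger amounts of compound), compound 1 `COc1ccc(C2CC(Nc3nc4ccc(C)cc4s3)=NN2C(C)=O)cc1O` gives 73.9 umol/kg, while compound 2 `CC(=O)N1N=C(Nc2nc3ccc(C)cc3s2)CC1c1ccc(Cl)cc1` gives 25.5 umol/kg, the lower of these two numbers. Compound 3 `CC(=O)N1N=C(Nc2nc3ccc(C)cc3s2)CC1c1ccccc1` has not yet been measured. It differs from compound 2 in one place, with hydrogen in place of chloro on an aromatic carbon, (hydrogen in place of chloro on an aromatic carbon), so 4-chlorophenyl becomes phenyl. Among the measured compounds shown here, only one measured step concerns this same ring, and it is modest: a 2.9-fold lower number from compound 1 to compound 2 (0.46 log units; beyond the scatter). That step replaced two groups on the ring with a chloro group, whereas the coming change removes a single atom. A smaller shift is therefore expected in this assay, drifting toward a higher number and probably not clearing the usual scatter. The expected step is a 1.6-fold higher number from compound 2 to compound 3 (0.22 log units; within the scatter). For compound 3, the estimated value is 42 umol/kg, within an expected range of 18 umol/kg to 95 umol/kg.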

Compound 3, dose for half-maximal effect: 106 umol/kg
Estimate against measurement, compound 3: 2.5-fold (0.40 log units) below; measured number outside the range, above it.
By their numbers in this assay, from the lowest: compound 2; then compounds 1 and 3 (each within the scatter of the next).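

In this assay the single chloro atom on this aromatic carbon turns out to matter: replacing it with hydrogen gives a 4.2-fold higher number from compound 2 to compound 3 (0.62 log units; beyond the scatter) and so loses the advantage of compound 2. The 3-hydroxy-4-methoxyphenyl and bare phenyl rings cannot be told apart, with a 1.4-fold higher number from compound 1 to compound 3 (0.16 log units; within the scatter) and no difference beyond the scatter, so among these three compounds only the 4-chlorophenyl ring stands out. Nothing available explains why this one atom makes such a difference.

From the compounds shown here alone, it remains open whether the effect is particular to chloro or would also appear with fluoro, bromo, methyl or an amine on the same aromatic carbon. Also open, going by these compounds, is how a hydroxy or a methoxy group alone would compare with the pair in compound 1.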